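From Amide to Acid at the Limit of Detection

The source may hold more compounds than are shown below. What is called first, only, known or untested is meant among the compounds shown, and "the series" means these compounds.

Compound 1 `C=CC1=C(C(=O)Nc2cccc(C)c2)C(c2ccc(F)cc2)OC1` gives > 100000 nM in a functional assay on SW480 cells (Homo sapiens) for cytotoxicity, read by MTT assay, with a stated time of 24 h (a lower number here means a stronger inhibitor, a higher number a weaker inhibitor), which is a limit of the assay.
Compound 2 `C=CC1=C(C(=O)NCCCCC)C(c2ccc(F)cc2)OC1` gives > 100000 nM in this assay, again a limit.
Compound 3 `C=CC1=C(C(=O)NCC(C)C)C(c2ccc(F)cc2)OC1` gives > 100000 nM in this assay, also a limit.

Compound 3 therefore stands at the limit, the same place as the other two measured compounds, as the limit of > 100000 nM in this assay, at which 3 of the 3 values shown sit, records. The three steps among them, a step that the two limits leave unreadable from compound 1 to compound 2, a step that the two limits leave unreadable from compound 1 to compound 3 and a step that the two limits leave unreadable from compound 2 to compound 3, cannot be read because the limit of > 100000 nM in this assay, at which 3 of the 3 values shown sit, caps every value. Nothing in this set shows whether any of the amide substituents changes cytotoxicity.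

Compound 4 `C=CC1=C(C(=O)O)C(c2ccc(F)cc2)OC1` is the acid of the shared core. Its difference from compound 3 is hydroxy in place of isobutylamino on a carbonyl carbon. For the measured compounds named here, the steps that bear on it are the changes at the amide nitrogen, a step that the two limits leave unreadable from compound 1 to compound 3 and a step that the two limits leave unreadable from compound 2 to compound 3, but both are unreadable, so no size or direction of step can be drawn from them for this assay.

With every measured value sitting at the limit, compound 4 is expected most likely to remain there as well. The expected step for compound 4 is a step that the limit leaves unreadable from compound 3 to compound 4. Compound 4 is expected to give 150000 nM, with a range from 50000 nM to 500000 nM.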

Compound 4, half-maximal inhibitory concentration: > 100000 nM
Compound 4: a limit, no number; the forecaster's own chance of this, stated with the estimate: 85%; the middle value lies beyond the limit too.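

In this assay compound 4 gives > 100000 nM as a limit and not a number. For the compounds shown here, no step from compound 1, compound 2 or compound 3 to compound 4 can be read, because all four values share one cap: the limit of > 100000 nM in this assay, at which 4 of the 4 values shown sit. The compounds shown leave open whether any group on the carbonyl carbon of the shared core changes the result in this assay at all.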